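Growth inhibition series: from methoxy to dimethylamino

The source may report more compounds than this note shows. Statements on the series, on what has been measured and on what is new or still open speak of the compounds shown alone.

In a functional assay on Gurav cells (Homo sapiens) for inhibition, read by sulforhodamine B assay (on this read-out lower numbers stand for stronger inhibition of growth and higher numbers for weaker inhibition of growth), compound 1 (`Fc1ccc(-c2ccc(-c3ccc(-c4nc5ccccc5[nH]4)cc3)cc2)cc1`) gives 100000 nM. Among the compounds with values here, compound 2 (`COc1ccc(-c2ccc(-c3ccc(-c4nc5ccccc5[nH]4)cc3)cc2)cc1`) gives 38100 nM, the lower of the two numbers so far. Within the data shown here, the only measured step, a 2.6-fold lower number from compound 1 to compound 2 (0.42 log units; beyond the scatter), is modest and comes with methoxy in place of fluoro on an aromatic carbon. Compound 3 (`CN(C)c1ccc(-c2ccc(-c3ccc(-c4nc5ccccc5[nH]4)cc3)cc2)cc1`) has not been measured. It carries dimethylamino in place of methoxy on an aromatic carbon, para to a large group: dimethylamino in place of methoxy on an aromatic carbon. Among the measured compounds shown here, the single measured step bears on this change only indirectly, as it exchanges a different pair of groups, and no measured compound carries dimethylamino. A further modest move towards a lower number is therefore expected, similar in size to that step, with low confidence. The expected step is a 2.4-fold lower number from compound 2 to compound 3 (0.38 log units; beyond the scatter). For compound 3 the estimated value is 16000 nM, with an expected range of 5000 nM to 50000 nM.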

Compound 3, concentration for 50% growth inhibition: 100000 nM
Beside the measured number, compound 3's estimate is 6.3-fold (0.80 log units) below it, and the stated range ends below it.
By their numbers in this assay, from the lowest: compound 2; then compounds 1 and 3 (each within the scatter of the next).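

At this position, on an aromatic carbon para to a large group, this assay shows a 2.6-fold higher number from compound 2 to compound 3 (0.42 log units; beyond the scatter) with dimethylamino in place of methoxy, so the lower number seen with methoxy does not extend to dimethylamino. Against fluoro, the same group gives no change at the digits printed from compound 1 to compound 3 (within the scatter) and methoxy is the only one of the three groups with a lower number. Nothing available here explains why methoxy and dimethylamino differ.

On these data alone, whether the lower number is particular to methoxy or is shared by other groups joined through oxygen, such as ethoxy or hydroxyl, remains open. As far as these compounds go, the outcome with a primary amine or a carboxylic acid at this position, and whether any group here can give a number well under that of compound 2, is also open.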